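Replacing the side chain of compound 2

The compounds below may be only part of what the source reports. "The series", "measured", "known", "first", "only" and "open" are said of these compounds alone.

In a functional assay on HeLa cells (Homo sapiens) for cytotoxicity, read by MTT assay (a higher number here means a weaker inhibitor, a lower number a stronger inhibitor), compound 1 `COC(C)CO[C@H](CC=C(C)C)C1=CC(=O)c2c(O)ccc(O)c2C1=O` gives 53400 nM and compound 2 `COCCO[C@H](CC=C(C)C)C1=CC(=O)c2c(O)ccc(O)c2C1=O` gives 62400 nM, two values within the scatter of each other. Compound 3 `CC[C@](C)(O)CC(=O)O[C@H](CC=C(C)C)C1=CC(=O)c2c(O)ccc(O)c2C1=O` carries (2-hydroxy-2-methylbutyl)carbonyl in place of 2-methoxyethyl on an oxygen on a saturated carbon. Among the measured compounds shown here, the only measured step is a 1.2-fold higher number from compound 1 to compound 2 (0.07 log units; within the scatter), with hydrogen in place of methyl. It stays within the scatter, so it offers little guidance for this much larger change. A tentative expectation is a clearly lower number, an estimated 3.5-fold lower number from compound 2 to compound 3 (0.54 log units; beyond the scatter). The estimate for compound 3 is 18000 nM, with an expected range of 3000 nM to 70000 nM.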

Compound 3, half-maximal inhibitory concentration: 30200 nM
Compound 3: middle estimate off by 1.7-fold (0.22 log units), on the low side; the range from low to high includes it.
By their numbers in this assay, from the lowest: compounds 3, 1 and 2 (each within the scatter of the next, the first and the last beyond it).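

In this assay, placing (2-hydroxy-2-methylbutyl)carbonyl on this oxygen gives a 2.1-fold lower number from compound 2 to compound 3 (0.32 log units; beyond the scatter), a modest step and the first here beyond the scatter. Against the 2-methoxypropyl chain, the same group gives a 1.8-fold lower number from compound 1 to compound 3 (0.25 log units; within the scatter), so the change stands out against only one of the two earlier side chains. No measurement here explains the shift.

The compounds shown do not separate the carbonyl from the hydroxyl or the branched chain of the new group. A plain acetyl group or a chain ending in an amine on the same oxygen remains an open comparison.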